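A few compounds are considered here, and "the series" means these few. Any claim that something is new, unique, unknown or untested is made for them only; others in the source may bear on it.

Compound 3 `COc1ccc(-c2nc3c(C(=O)NCCCO)cccc3[nH]2)cc1OC` was examined in an ADME assay on Vero cells (Chlorocebus sabaeus) for cytotoxicity (a higher number here means that more compound is tolerated, a lower number that less compound is tolerated), and gave 46 uM. Among the three measured compounds it sits close to its companions: compound 1 `O=C(Nc1ccccc1)c1cccc2[nH]c(-c3ccncc3)nc12` gives 49.8 uM in this assay, a number within the usual scatter of compound 3, and compound 2 `O=C(Nc1ccccc1F)c1cccc2[nH]c(-c3ccco3)nc12` gives 25 uM, which also lies within that scatter. Within the data shown here, the three measured numbers therefore form a narrow band, and no compound among them can be called better or worse tolerated than another.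

Compound 4 `COc1ccc(-c2nc3c(C(=O)Nc4cnc(Cl)cn4)cccc3[nH]2)cc1OC` has not yet been measured in this assay. It differs from compound 3 at a single place: 5-chloropyrazin-2-yl in place of 3-hydroxypropyl on an amide-type nitrogen. The rest of the shared core and the dimethoxyphenyl substituent are kept unchanged. Among the measured compounds shown here, no step between two measured compounds that differ at only this place is available, so the expectation for compound 4 rests on the band formed by compounds 1, 2 and 3. In this assay compound 4 is expected to give a number near that band, with the step of a 1.5-fold lower number from compound 3 to compound 4 (0.19 log units; within the scatter) expected to fall at or near the edge of the scatter, leaning slightly downward. The estimate for compound 4 in this assay is 30 uM, with a range from 12 uM to 80 uM.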

Compound 4, half-maximal toxic concentration: 78.3 uM
Compound 4: the middle estimate sits 2.6-fold (0.42 log units) below what was measured, within the range that was stated.
By their numbers in this assay, from the lowest: compounds 2, 3, 1 and 4 (each within the scatter of the next, the first and the last beyond it).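

In this assay, among these compounds, the exchange of 3-hydroxypropyl for 5-chloropyrazin-2-yl on the amide-type nitrogen gives a 1.7-fold higher number from compound 3 to compound 4 (0.23 log units; within the scatter) and is the only step that can be read at this place. It shows that an open chain bearing a hydroxyl group and a six-membered aromatic ring bearing chlorine can stand at this nitrogen with the shared core and the dimethoxyphenyl substituent unchanged, and that the two numbers stay within the scatter of each other, which compounds 1 and 2 could not show because they differ from compound 3 in more than one place. No measurement shown here offers an explanation for the numbers at this position.

This single step does not separate the contribution of the chlorine from that of the ring, so a plain pyrazin-2-yl group, a phenyl group or a 3-aminopropyl chain would be needed to divide the change into its parts. On these data alone, whether the same exchange reads alike with a pyridine or another ring in place of the dimethoxyphenyl substituent also remains open.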